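The compounds below may be only part of what the source reports. "The series", "measured", "known", "first", "only" and "open" are said of these compounds alone.

Compound 1, `COc1ccc2c(=O)c(/C=C/C(=O)Nc3cc(C)ccc3C)coc2c1`, gives 58400 nM in a functional assay on HeLa cells (Homo sapiens) for inhibition, read by MTT assay, with a stated time of 48 h; a higher number here means a weaker inhibitor, a lower number a stronger inhibitor.
Compound 2, `COc1ccc2c(=O)c(/C=C/C(=O)Nc3ccccc3)coc2c1`, reaches only the limit > 100000 nM.
Compound 3, `COc1ccc2c(=O)c(/C=C/C(=O)NCc3ccc(F)cc3)coc2c1`, reaches only the limit > 100000 nM.

Compound 2 thus stands at the edge of what this assay reports, namely (the limit of > 100000 nM in this assay, at which 2 of the 3 values shown sit). The unmeasured compound 4, `O=C(/C=C/c1coc2cc(O)ccc2c1=O)Nc1ccccc1`, differs from compound 2 by hydrogen in place of methyl on an oxygen on an aromatic ring. The two readable steps, an at least 1.7-fold higher number from compound 1 to compound 2 (0.23 log units; that floor lies within the scatter) and an at least 1.7-fold higher number from compound 1 to compound 3 (0.23 log units; that floor lies within the scatter), both concern groups on the amide-type nitrogen, not the oxygen on the aromatic ring, and each has a floor within the scatter. For the measured compounds named here, no measured step therefore bears on the change to compound 4, and no shift beyond the scatter is expected in either direction. Compound 4 is estimated at 100000 nM, with a range from 30000 nM to 300000 nM. For compound 4 the expected step is a number no higher from compound 2 to compound 4 (the limit leaves the size open).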

Compound 4, half-maximal inhibitory concentration: 9700 nM
Beside the measured number, compound 4's estimate is 10-fold (1.01 log units) above it, and the stated range ends above it.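

Hydrogen in place of methyl on the oxygen on the aromatic ring gives an at least 10-fold lower number from compound 2 to compound 4 (1.01 log units; beyond the scatter) in this assay. This is the only readable step among the compounds shown that lies beyond the scatter, and it sits at this oxygen, not on the amide-type nitrogen. Compound 2 enters this step only as a limit, so the full size of the step stays open: the limit of > 100000 nM in this assay, at which 2 of the 4 values shown sit.

From the compounds shown here alone, whether the same change gives a like step with 2,5-dimethylphenyl or 4-fluorobenzyl on the amide-type nitrogen remains open. So does how an ethoxy group or an amine would read at this place.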